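Removing one propanoyl ester from a nucleoside triester

This account rests on a few compounds, and the source may have more. Where it says the series, first, only, none or still open, it means among the compounds named here.

Compound 1 `CCC(=O)OC[C@H]1O[C@@H](n2cnc3c(OC)ncnc32)[C@@H](OC(=O)CC)[C@@H]1OC(=O)CC` carries three propanoyl esters on its sugar. In a physicochemical assay for metabolic stability, at pH 7 (a higher number here means that the compound lasts longer, a lower number that the compound disappears faster), compound 1 gives 3050 h, the second highest of the three numbers measured. Compound 2 `CCC(=O)O[C@H]1[C@H](OC(=O)CC)[C@@H](CO)O[C@H]1n1cnc2c(OC)ncnc21` keeps two of the esters and has a free hydroxyl at the remaining position; in this assay compound 2 gives 12600 h. Compound 3 `CCCCC(=O)OC[C@H]1O[C@@H](n2cnc3c(OC)ncnc32)[C@@H](OC(=O)CCCC)[C@@H]1O` has two longer pentanoyl esters and a free hydroxyl; in this assay compound 3 gives 1240 h. So compound 1 sits between them, with compound 3 lower and compound 2 higher.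

Compound 4 `CCC(=O)OC[C@H]1O[C@@H](n2cnc3c(OC)ncnc32)[C@@H](O)[C@@H]1OC(=O)CC` differs from compound 1 in one place: hydrogen in place of propanoyl on an oxygen on a saturated carbon. The same kind of change, a propanoyl replaced by hydrogen on an oxygen of a saturated carbon, is seen from compound 1 to compound 2, where it gave a 4.1-fold higher number from compound 1 to compound 2 (0.62 log units; beyond the scatter). That step sits on a different oxygen of the sugar, so it is only a rough guide, and compound 3 shows that an ester-to-hydroxyl pattern does not always go up. Here a smaller change is expected, with the estimated step being a 1.8-fold higher number from compound 1 to compound 4 (0.26 log units; within the scatter). Compound 4 is therefore estimated at 5500 h, with a range from 1500 h to 16000 h.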

Compound 4, half-life: 725 h
The estimate for compound 4 lay 7.6-fold (0.88 log units) above the measured number, and the stated range ends above it.
By their numbers in this assay, from the lowest: compounds 4 and 3 (each within the scatter of the next); then compound 1; then compound 2.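

The same change, propanoyloxy to hydroxy, gives a 4.2-fold lower number from compound 1 to compound 4 (0.62 log units; beyond the scatter) in this assay, whereas on another oxygen of the same triester it gave a 4.1-fold higher number from compound 1 to compound 2 (0.62 log units; beyond the scatter) in the same assay. Both steps lie beyond the usual scatter, so in this small set, replacing a propanoyl ester with a free hydroxyl has no single direction, and the outcome depends on which oxygen of the sugar loses its ester. Nothing given here explains why these two oxygens respond in opposite directions.

As far as these compounds go, it remains open whether the lower number at this oxygen is tied to the free hydroxyl itself, or whether a methyl ether or an amine on the same carbon would move the half-life in the same direction. From the compounds shown here alone, it is equally open whether the opposite directions at the two oxygens would persist if each propanoyl ester on the shared core were replaced by a butanoyl ester, a chain length that lies between the propanoyl and pentanoyl esters seen so far.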